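Swapping an Isopropyl Group for a Phenyl Group

The compounds below may be only part of what the source reports. "The series", "measured", "known", "first", "only" and "open" are said of these compounds alone.

Of the compounds shown here, three sharing one small ring core have been tested in a functional assay on MIA PaCa-2 cells (Homo sapiens) for inhibition; a lower number here means a stronger inhibitor, a higher number a weaker inhibitor. Compound 1 `CCC(C)C1NC(=O)N(C2CCCC2)C1=O` gives > 100000 nM, which is a limit of the assay rather than a number. Compound 2 `CC(C)C1NC(=O)N(C2CCCC2)C1=O` gives > 100000 nM, again a limit. Compound 3 `CCC(C)C1NC(=O)N(Cc2ccccc2)C1=O` gives > 100000 nM, also a limit. Within the data shown here, because every value sits at the limit of > 100000 nM in this assay, at which 3 of the 3 values shown sit, no order among the three can be read, and the single measured step between close neighbours, a step that the two limits leave unreadable from compound 1 to compound 2, is unreadable for the same reason.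

Compound 4 `O=C1NC(c2ccccc2)C(=O)N1C1CCCC1` has not yet been measured. It differs from compound 2 by phenyl in place of isopropyl on a saturated ring carbon, in words phenyl in place of isopropyl on a saturated ring carbon. Among the measured compounds shown here, no measured step involves a phenyl group at this place, and the one measured step gives no size at all, so nothing in the data points to a gain or a loss. Compound 4 is therefore expected to stay near the limit, with an estimate of 100000 nM and a range from 20000 nM to 300000 nM. This corresponds to an expected step of a number no higher from compound 2 to compound 4 (the limit leaves the size open), essentially none beyond the scatter.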

Compound 4, half-maximal inhibitory concentration: > 100000 nM
Compound 4: only a limit was reported (the forecaster's own chance of this, stated with the estimate: 75%); the middle value lies on the limit itself.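

Compound 4 ends up at a limit of the assay, as do compound 1 and compound 2, so neither step to compound 4 can be read: the limit of > 100000 nM in this assay, at which 4 of the 4 values shown sit. The compounds shown leave open whether any group at this place on the shared core gives a readable value in this assay.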